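Replacing naphthalen-2-yl with 4-chlorophenyl: notes on compound 3

The source may hold more compounds than are shown below. What is called first, only, known or untested is meant among the compounds shown, and "the series" means these compounds.

Measured in an ADME assay on HCT-116 cells (Homo sapiens) for cytotoxicity, read by CellTiter-Glo, with a stated time of 72 h; a higher number here means a weaker inhibitor, a lower number a stronger inhibitor:
- compound 1 `CC1CCN(C2CCN(S(=O)(=O)c3cccc(C(F)(F)F)c3)CC2)CC1` gives > 5000 nM, a limit
- compound 2 `CC1CCN(C2CCN(S(=O)(=O)c3cccc(-c4ccc5ccccc5c4)c3)CC2)CC1` gives > 5000 nM, a limit
- compound 3 `CC1CCN(C2CCN(S(=O)(=O)c3cccc(-c4ccc(Cl)cc4)c3)CC2)CC1` is not yet measured

Compound 2 stands only at > 5000 nM, which is a limit and not a number. Among the measured compounds shown here, the sole evidence is the limit of > 5000 nM in this assay, at which 2 of the 2 values shown sit. Compound 3 has 4-chlorophenyl in place of naphthalen-2-yl on an aromatic carbon, meta to a large group, as 4-chlorophenyl in place of naphthalen-2-yl on an aromatic carbon shows. The one measured bearing on this change is a step that the two limits leave unreadable from compound 1 to compound 2, so it supplies no size to carry over. No step beyond the scatter is expected in this assay, and no direction can be assigned. The expected step is a step that the limit leaves unreadable from compound 2 to compound 3 as an estimate. Compound 3 is estimated at 7000 nM, with an expected range of 3000 nM to 15000 nM, and another report as a limit is likely.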

Compound 3, half-maximal inhibitory concentration: > 5000 nM
Compound 3 gave a limit, no number (the forecaster's own chance of this, stated with the estimate: 85%); the middle value lies beyond the limit too.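

No new step can be read in this assay: compound 1, compound 2 and compound 3 all stand at a limit. The compounds shown leave open whether any group at this place would give a number rather than a limit.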